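Benzyl in Place of Methylphenyl on the Hydroxy Carbon

The source may report more compounds than this note shows. Statements on the series, on what has been measured and on what is new or still open speak of the compounds shown alone.

Compound 1 `Cc1cccc([C@@H](O)C(=O)N2N=CC[C@H]2C(=O)NCc2cc(Cl)ccc2-n2cnnn2)c1` gives 9.7 10^-6 cm/s in an ADME assay on Caco-2 cells (Homo sapiens) for permeability, read by LC-MS, in the apical to basolateral direction, with a stated time of 60 min, at pH 6.5; a lower number here means that the compound crosses the layer more slowly, a higher number that the compound crosses the layer faster.
Compound 2 `O=C(NCc1cc(Cl)ccc1-n1cnnn1)[C@@H]1[C@@H]2C[C@@H]2CN1C(=O)[C@H](O)c1ccccc1` gives 2.2 10^-6 cm/s in this assay.
Compound 3 `CC(C)(C)[C@@H](O)C(=O)N1CCS[C@H]1C(=O)NCc1cc(Cl)ccc1-n1cnnn1` gives 5.2 10^-6 cm/s in this assay.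

Among these three, compound 1 carries the highest number in this assay. The gap to compound 3 lies within the usual scatter of repeated measurements, so those two cannot be told apart; only the gap to compound 2 lies beyond the scatter, and compound 2 crosses the cell layer more slowly than compound 1.

Compound 4 `O=C(NCc1cc(Cl)ccc1-n1cnnn1)[C@@H]1CC=NN1C(=O)[C@H](O)Cc1ccccc1` has not yet been measured. It shares its core with compound 1 and differs from it by benzyl in place of 3-methylphenyl on a saturated chain carbon bound to a carbonyl carbon and an oxygen on a saturated carbon. Among the measured compounds shown here, no pair of measured compounds shows this change, so there is no measured step to lean on. The two structures hold the same atoms joined differently, and the change keeps the counts of donors and acceptors unchanged. A step in this assay from compound 1 to compound 4 is expected to stay within the scatter, leaning if anything a little lower. Compound 4 is therefore estimated at 7 10^-6 cm/s, within a range from 3.5 10^-6 cm/s to 14 10^-6 cm/s. That estimate is expected to amount to a step of a 1.4-fold lower number from compound 1 to compound 4 (0.14 log units; within the scatter).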

Compound 4, apparent permeability: 11 10^-6 cm/s
Estimate against measurement, compound 4: 1.6-fold (0.20 log units) below; measured number inside the range.
By their numbers in this assay, from the lowest: compound 2; then compounds 3, 1 and 4 (each within the scatter of the next, the first and the last beyond it).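

Benzyl in place of 3-methylphenyl on a saturated chain carbon bound to a carbonyl carbon and an oxygen on a saturated carbon gives a 1.1-fold higher number from compound 1 to compound 4 (0.05 log units; within the scatter) in this assay. This is the only measured step at this position among the compounds shown, and on this core the two groups cannot be told apart in this read-out. Nothing measured here bears on what lies behind this result.

On these data alone, whether an amine, a carboxylic acid or a longer chain at this position would also leave the number in this assay within the scatter remains open. So does whether the same exchange would give a similar step on the cores of compound 2 and compound 3, which differ from compound 1 in more than one place.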